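This account rests on a few compounds, and the source may have more. Where it says the series, first, only, none or still open, it means among the compounds named here.

Measured so far in an ADME assay on MT4 cells (Homo sapiens) for cytotoxicity, read by MTT assay, with a stated time of 96 h; a lower number here means that less compound is tolerated, a higher number that more compound is tolerated:
compound 2 `Oc1ccc(-c2nc3cc(Cl)c(Cl)cc3[nH]2)cc1` gives 12000 nM
compound 1 `Cn1c(-c2ccc(NC(=O)CN3CCCC3)cc2)nc2cc(C(F)(F)F)ccc21` gives 16000 nM
compound 3 `O=C(O)CCC(=O)Nc1ccc(-c2nc3cc(C(F)(F)F)ccc3[nH]2)cc1` gives only a limit of the assay, > 100000 nM

Compound 2 has the lowest of the two plain numbers in this assay; compound 1 is nearest, and the gap between the two is within the scatter, so no order between them is claimed. Compound 3 sits at the limit of > 100000 nM in this assay, at which 1 of the 3 values shown sits. Compound 4 `CC(=O)Nc1ccc(-c2nc3cc(Cl)c(Cl)cc3[nH]2)cc1` is not yet measured; it differs from compound 2 by acetamido in place of hydroxy on an aromatic carbon. Going by the values given here, no measured pair isolates this change, so its size cannot be read off; in this assay the number for compound 4 is expected to move little, if anything upward, with nothing beyond the scatter assured. Compound 4 is estimated at 20000 nM, range 6000 nM to 70000 nM. This estimate means an expected step of a 1.7-fold higher number from compound 2 to compound 4 (0.22 log units; within the scatter).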

Compound 4, half-maximal cytotoxic concentration: > 100000 nM
Compound 4: a limit, no number; the forecaster's own chance of this, stated with the estimate: 25%; middle value at least 5.0-fold (0.69 log units) away from the limit.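

In this assay, going by these compounds alone, acetamido in place of hydroxy on an aromatic carbon gives an at least 8.3-fold higher number from compound 2 to compound 4 (0.92 log units; beyond the scatter), the first change isolated at one place and a step beyond the scatter. Compound 4 gives > 100000 nM, which is a limit of the assay and not a number, so the step has a lower bound only. The top of the measurable range is now reached twice: the limit of > 100000 nM in this assay, at which 2 of the 4 values shown sit.

Still open, as far as these compounds go, is how an amine or a longer acyl chain in place of acetamido on this carbon would read. Also open, from the compounds shown here alone, is whether the step holds with trifluoromethyl in place of the two chlorines on the core.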